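Ethyl to difluorophenyl on the sulfonamide: notes toward compound 3

A few compounds are considered here, and "the series" means these few. Any claim that something is new, unique, unknown or untested is made for them only; others in the source may bear on it.

Going by the values given here, compound 1 `CCS(=O)(=O)Nc1cc(-c2ccc3ncnc(Nc4cccc(C(=O)OC)c4)c3c2)cnc1OC` gives 1080 nM in a functional assay on BT-549 cells (Homo sapiens) for cytotoxicity, read by sulforhodamine B assay, with a stated time of 72 h (on this read-out lower numbers stand for stronger inhibition and higher numbers for weaker inhibition), the lowest of the two numbers so far. Compound 2 `CCS(=O)(=O)Nc1cc(-c2ccc3ncnc(Nc4ccc(F)c(C(=O)OC)c4)c3c2)cnc1OC` gives 2740 nM in this assay; the step of a 2.5-fold higher number from compound 1 to compound 2 (0.40 log units; beyond the scatter) is beyond the scatter but modest. Compound 3 `COC(=O)c1cccc(Nc2ncnc3ccc(-c4cnc(OC)c(NS(=O)(=O)c5ccc(F)cc5F)c4)cc23)c1` differs from compound 1 by 2,4-difluorophenyl in place of ethyl on a sulfonyl sulfur. Among the compounds with values here, no measured step touches the sulfonyl substituent; the single measured step concerns an aromatic hydrogen elsewhere and offers no direction here. The step of a 1.0-fold higher number from compound 1 to compound 3 (0.01 log units; within the scatter) is therefore expected to stay within the usual scatter. Compound 3 is estimated at 1100 nM, with a range of 300 nM to 4500 nM.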

Compound 3, half-maximal inhibitory concentration: 12700 nM
The estimate for compound 3 lay 12-fold (1.06 log units) below the measured number; measured number above the stated range.
By their numbers in this assay, from the lowest: compound 1; then compound 2; then compound 3.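

In this assay the substituent on the sulfonyl sulfur is far from neutral: 2,4-difluorophenyl in place of ethyl gives a 12-fold higher number from compound 1 to compound 3 (1.07 log units; beyond the scatter) and marks this as a sensitive place in the series. This step is large, whereas the fluoro step on the aromatic carbon was modest, and compound 1 with its ethyl keeps the lowest number of the three.

From the compounds shown here alone, whether the ring itself or its two fluorines drive the step stays open, as does the reading of methyl, a longer alkyl chain or unsubstituted phenyl on the sulfonyl sulfur. Nothing in hand accounts for the size of this step.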